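A few compounds are considered here, and "the series" means these few. Any claim that something is new, unique, unknown or untested is made for them only; others in the source may bear on it.

Compounds measured so far:
compound 1, `Fc1ccc(C2CC(c3ccccc3)=NN2c2ccc(-c3ccccc3)nn2)cc1`, 100000 nM
compound 2, `COc1ccc(C2CC(c3ccccc3)=NN2c2ccc(-c3ccccc3)nn2)cc1`, 100000 nM

Both were tested in a functional assay on MCF7 cells (Homo sapiens) for antiproliferative activity, read by MTT assay, with a stated time of 24 h; on this read-out lower numbers stand for stronger inhibition and higher numbers for weaker inhibition. Compound 1 gives 100000 nM and compound 2 gives 100000 nM, so compound 2 stands level with compound 1 on the numbers shown; the step of no change at the digits printed from compound 1 to compound 2 (within the scatter) lies within the scatter. Going by the values given here, compound 3, `COc1ccc(C2CC(c3ccccc3)=NN2c2ccc(-c3ccccc3)nn2)c(OC)c1`, has not been measured; it differs from compound 2 by methoxy in place of hydrogen on an aromatic carbon, a change for which no measured step exists. Among the compounds with values here, the one measured step, from compound 1 to compound 2, was flat, so no shift beyond the scatter is expected. Compound 3 is expected at 100000 nM, with a range of 40000 nM to 100000 nM, a step of no change at the digits printed from compound 2 to compound 3 (within the scatter).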

Compound 3, half-maximal inhibitory concentration: > 100000 nM
Compound 3: no number, only a limit (the forecaster's own chance of this, stated with the estimate: 10%); the middle value lies on the limit itself.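

In this assay compound 3 gives > 100000 nM, which is a limit of the assay and not a number. The data print a number no lower from compound 2 to compound 3 (the limit leaves the size open) and also a number no lower from compound 1 to compound 3 (the limit leaves the size open) and neither of these steps can be read, so the added methoxy, ortho to a large group, shows only that this 2,4-dimethoxyphenyl form brought no stronger inhibition: the limit of > 100000 nM in this assay, at which 1 of the 3 values shown sits.

The compounds shown leave open whether any group at this position would give a readable value. A hydroxyl, an amine or a carboxylic acid there remains an open case.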